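A few compounds are considered here, and "the series" means these few. Any claim that something is new, unique, unknown or untested is made for them only; others in the source may bear on it.

The measured compounds:
compound 1 `CCN(CC)CCCNC(=O)c1ccc(C(CC)(CC)c2ccc(C#CC(O)(CC)CC)c(C)c2)n1CC`, which in an assay on cells for agonist activity at vitamin D3 receptor (Homo sapiens), read by microscopy (on this read-out higher numbers stand for an effect only at larger amounts of compound and lower numbers for an effect already at smaller amounts), gives 68.9 nM
compound 2 `CCn1c(C(=O)NCCCO)ccc1C(CC)(CC)c1ccc(C#CC(O)(CC)CC)c(C)c1`, which in this assay gives 137 nM
compound 3 `CCn1cc(C(CC)(CC)c2ccc(C#CC(O)(CC)CC)c(C)c2)cc1C(=O)NCCN(C)C`, which in this assay gives 19.3 nM

Compound 3 stands lowest of the three numbers in this assay; its gap to compound 1, the nearest, and its gap to compound 2, the furthest, both lie beyond the scatter. Compound 4 `CCCCC(=O)c1cc(C(CC)(CC)c2ccc(C#CC(O)(CC)CC)c(C)c2)cn1CC` is not yet measured. It differs from compound 3 by butyl in place of (2-(dimethylamino)ethyl)amino on a carbonyl carbon. The change therefore removes the amide-type nitrogen together with its dimethylamino chain and leaves a ketone on the shared core.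

Among the compounds with values here, only one measured step touches this region: a 2.0-fold higher number from compound 1 to compound 2 (0.30 log units; within the scatter). That step swapped the basic amine for a hydroxy while the amide was kept, and the number barely moved. Within the data shown here, the step to compound 4 goes further, taking away both the amine and the amide nitrogen, and no measured pair shows what the amide itself contributes. A modest rise in the number in this assay, somewhat larger than the step from compound 1 to compound 2, is therefore expected rather than a large one. For compound 4 the step of a 2.8-fold higher number from compound 3 to compound 4 (0.45 log units; beyond the scatter) is the estimate, giving an expected value of 55 nM with a range from 15 nM to 200 nM.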

Compound 4, half-maximal effective concentration: > 50 nM
Compound 4 ended at the assay's limit; the forecaster's own chance of this, stated with the estimate: 5%; the middle value lies beyond the limit too.
By their numbers in this assay, from the lowest: compound 3; then compounds 1 and 2 (each within the scatter of the next).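

In this assay compound 4 gives > 50 nM, and this value is a limit of the assay, not a number. Even so, an at least 2.5-fold higher number from compound 3 to compound 4 (0.41 log units; beyond the scatter) shows that on this carbonyl carbon, butyl in place of (2-(dimethylamino)ethyl)amino moves the number by a margin that can be read, whereas the only earlier step, a 2.0-fold higher number from compound 1 to compound 2 (0.30 log units; within the scatter), changed the end of the chain while the amide stayed and did not leave the scatter. The true size of the new step remains open on the upper side, and the reading ends at the limit of the assay: the limit of > 50 nM in this assay, at which 1 of the 4 values shown sits.

This single change removes the amide-type nitrogen and the dimethylamino end of the chain together, so the compounds shown cannot say which of the two accounts for the rise in the number. An amide on this carbonyl carbon that carries a plain butyl chain, or a hydroxy in place of the dimethylamino group on the same ethyl chain, would separate the two contributions, and a carboxylic acid at this carbon would test whether any chain is needed there at all.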